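Extending the acyl group on compound 3's pyrrolidine

The compounds below may be only part of what the source reports. "The series", "measured", "known", "first", "only" and "open" are said of these compounds alone.

Of the compounds shown here, three sharing one core have been measured in an assay on isolated protein for binding affinity to secreted frizzled-related protein 1 (Homo sapiens), read by fluorescence; on this read-out higher numbers stand for weaker inhibition and lower numbers for stronger inhibition. Compound 1 `CN(C)CC(=O)N1CCC(NS(=O)(=O)c2cc(S(=O)(=O)c3ccccc3)ccc2C(F)(F)F)CC1` gives 300 nM, compound 2 `O=C(CN1CCCC1)N1CCC(NS(=O)(=O)c2cc(S(=O)(=O)c3ccccc3)ccc2C(F)(F)F)CC1` gives 110 nM, and compound 3 `CC(=O)N1CCC[C@H]1C(=O)N1CCC(NS(=O)(=O)c2cc(S(=O)(=O)c3ccccc3)ccc2C(F)(F)F)CC1` gives 160 nM. The value of compound 3 lies between the other two: the step of a 1.5-fold higher number from compound 2 to compound 3 (0.16 log units; within the scatter) and the step of a 1.9-fold lower number from compound 1 to compound 3 (0.27 log units; within the scatter) are both within the scatter, while the step of a 2.7-fold lower number from compound 1 to compound 2 (0.44 log units; beyond the scatter) is the only one beyond it.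

Compound 4 `CC(C)(C)CC(=O)N1CCC[C@H]1C(=O)N1CCC(NS(=O)(=O)c2cc(S(=O)(=O)c3ccccc3)ccc2C(F)(F)F)CC1` is the next compound. Relative to compound 3 the change is tert-butyl in place of hydrogen on a saturated chain carbon bound to a carbonyl carbon. Within the data shown here, none of the measured steps touches this position; all three alter the group on the other side of the amide carbonyl, and the two steps that involve the acetylpyrrolidine part stay within the scatter. Among the measured compounds shown here, there is thus no measured step that points to a change in this assay, so the estimate for compound 4 is 160 nM, expected to fall between 70 nM and 360 nM, which means an expected step of no change at the digits printed from compound 3 to compound 4 (within the scatter).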

Compound 4, half-maximal inhibitory concentration: 20 nM
The estimate for compound 4 lay 8.0-fold (0.90 log units) above the measured number; the whole stated range lies above it.
By their numbers in this assay, from the lowest: compound 4; then compounds 2, 3 and 1 (each within the scatter of the next, the first and the last beyond it).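

In this assay, among these compounds, the acyl group on the pyrrolidine proves able to move the number: tert-butyl on the saturated chain carbon bound to a carbonyl carbon gives a clear drop (an 8.0-fold lower number from compound 3 to compound 4 (0.90 log units; beyond the scatter)), at a position that no earlier step had touched. Compound 4 also lies beyond the scatter from the other two compounds (a 5.5-fold lower number from compound 2 to compound 4 (0.74 log units; beyond the scatter); a 15-fold lower number from compound 1 to compound 4 (1.18 log units; beyond the scatter)), which makes it the most potent of the four in this binding measurement. Nothing available explains why this added group lowers the number.

The compounds shown leave open whether a smaller ethyl group, a cyclohexyl ring or an amine on this same carbon would lower the number as well. They also leave open how much of the drop depends on the full tert-butyl group rather than on a longer chain alone.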